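Removing the nitro group from a weak myosin-2 inhibitor

The compounds below may be only part of what the source reports. "The series", "measured", "known", "first", "only" and "open" are said of these compounds alone.

Measured compounds:
- compound 1, `C/C(=N\C(C)C)c1c(O)c2ccccc2oc1=O`: >= 100000 nM
- compound 2, `C/C(=N\CCCO)c1c(O)c2ccccc2oc1=O`: 37000 nM
- compound 3, `CCCCC/N=C(\C)c1c(O)c2cc([N+](=O)[O-])ccc2oc1=O`: >= 100000 nM

The three measured compounds share one core and were tested in an assay on isolated protein for inhibition of myosin-2 (Bos taurus), read by spectrophotometry, with a stated time of 24 min; a lower number here means a stronger inhibitor, a higher number a weaker inhibitor. Compound 1 reaches only the limit of this assay, at >= 100000 nM. Compound 2 gives a number, 37000 nM, and the step of an at least 2.7-fold lower number from compound 1 to compound 2 (0.43 log units; beyond the scatter). Compound 3 also sits at the limit, >= 100000 nM, so for compound 3 only a boundary is known, not a number, and it shares that position with compound 1 (the limit of >= 100000 nM in this assay, at which 2 of the 3 values shown sit).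

The unmeasured compound 4, `CCCCC/N=C(\C)c1c(O)c2ccccc2oc1=O`, differs from compound 3 in one place: hydrogen in place of nitro on an aromatic carbon. Going by the values given here, none of the measured steps changes a group on the aromatic ring; the only measured step, from compound 1 to compound 2, concerns the chain on the double-bonded nitrogen. So no measured step bears on this change, and there is no evidence to expect a step beyond the scatter in either direction in this assay.

For compound 4, then, the estimate is 90000 nM, between 30000 nM and 200000 nM, which means an expected step of an at least 1.1-fold lower number from compound 3 to compound 4 (0.04 log units; that floor lies within the scatter), with a substantial chance that compound 4 too comes back only as a limit.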

Compound 4, half-maximal inhibitory concentration: 6700 nM
Compound 4: middle estimate off by 13-fold (1.13 log units), on the high side, outside the stated range (below it).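

Going by these compounds alone, changing a group on the aromatic ring, which no earlier step had touched, turns out to matter a great deal: with the pentyl chain kept, hydrogen in place of nitro gives an at least 14-fold lower number from compound 3 to compound 4 (1.17 log units; beyond the scatter), and a compound at the limit becomes one with a real number. The chain on the double-bonded nitrogen also counts, since pentyl in place of isopropyl gives an at least 14-fold lower number from compound 1 to compound 4 (1.17 log units; beyond the scatter) and ethyl in place of hydroxy gives a 5.5-fold lower number from compound 2 to compound 4 (0.74 log units; beyond the scatter), which makes compound 4 the strongest of the four compounds shown. The steps from compound 3 and compound 1 are floors rather than exact sizes, because each starts from a compound with no number, only a limit: the limit of >= 100000 nM in this assay, at which 2 of the 4 values shown sit.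

Among the compounds shown, only nitro and hydrogen can be compared at this ring carbon, so it stays open whether a chlorine, a methoxy or an amine there would behave more like nitro or more like hydrogen. On these data alone, it also stays open whether a chain longer than pentyl, or one ending in a carboxylic acid, would lower the number further.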